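The source may report more compounds than this note shows. Statements on the series, on what has been measured and on what is new or still open speak of the compounds shown alone.

Compound 1 `Cc1c(C(=O)N/N=C\c2cccc(O)c2O)oc2cccc(O)c12`: 5030 nM
Compound 2 `Cc1ccc(O)c(/C=N\NC(=O)c2oc3cccc(O)c3c2C)c1`: 5990 nM

Going by the values given here, in a functional assay on MGC-803 cells (Homo sapiens) for inhibition, read by MTT assay (a higher number here means a weaker inhibitor, a lower number a stronger inhibitor), compound 2 has the highest of the two numbers measured so far, though its nearest neighbour, compound 1, sits only a 1.2-fold higher number from compound 1 to compound 2 (0.08 log units; within the scatter) away. Compound 3 `Cc1c(C(=O)N/N=C\c2ccc(Br)cc2O)oc2cccc(O)c12` differs from compound 2 in one place: 4-bromo-2-hydroxyphenyl in place of 2-hydroxy-5-methylphenyl on a carbon with a double bond to nitrogen. Among the compounds with values here, the only measured step that bears on this, a 1.2-fold higher number from compound 1 to compound 2 (0.08 log units; within the scatter), also exchanged the ring on that carbon and stayed within the scatter, so no step beyond the scatter is expected here: a 1.1-fold lower number from compound 2 to compound 3 (0.04 log units; within the scatter). Compound 3 is therefore estimated at 5500 nM, with a range from 2500 nM to 12000 nM.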

Compound 3, half-maximal inhibitory concentration: 5460 nM
Compound 3: the middle estimate sits 1.0-fold (0.00 log units) above what was measured; the range from low to high includes it.
By their numbers in this assay, from the lowest: compounds 1, 3 and 2 (each within the scatter of the next).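

Going by these compounds alone, on the carbon with a double bond to nitrogen, bromine now enters for the first time, yet in this assay the step stays small: a 1.1-fold lower number from compound 2 to compound 3 (0.04 log units; within the scatter) and a 1.1-fold higher number from compound 1 to compound 3 (0.04 log units; within the scatter). So 4-bromo-2-hydroxyphenyl cannot be told apart from either earlier ring, and all three changes at this place now lie within the scatter. No measurement on hand explains this lack of change.

All three rings still carry the 2-hydroxy group. On these data alone, whether plain phenyl, or a ring bearing an amine or a carboxylic acid, would move the number beyond the scatter remains open.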